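A few compounds are considered here, and "the series" means these few. Any claim that something is new, unique, unknown or untested is made for them only; others in the source may bear on it.

Measured compounds in a functional assay on MCF7 cells (Homo sapiens) for cytotoxicity, read by MTT assay, with a stated time of 4 days; a higher number here means a weaker inhibitor, a lower number a stronger inhibitor:
- Compound 1 `C=C1C[C@]23C[C@@]1(O)CC[C@H]2c1ccc(O)c(C)c1[C@@H]3Cn1cc(-c2ccc(Br)cc2)nn1` gives > 20000 nM, which is a limit of the assay.
- Compound 2 `C=C1C[C@]23C[C@@]1(O)CC[C@H]2c1ccc(O)c(C)c1[C@@H]3Cn1cc(-c2ccc(F)cc2)nn1` gives > 20000 nM, also a limit of the assay.
- Compound 3 `C=C1C[C@]23C[C@@]1(O)CC[C@H]2c1cc(Br)c(O)c(C)c1[C@@H]3Cn1cc(-c2ccc(Cl)cc2)nn1` gives 10200 nM.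

Compound 3 is the only one of the three with an actual number; the other two values sit at the limit of > 20000 nM in this assay, at which 2 of the 3 values shown sit. Among the compounds with values here, the single measured step, from compound 1 to compound 2, is a step that the two limits leave unreadable from compound 1 to compound 2, a change of fluoro for bromo on the pendant aromatic ring, so it says nothing about the size of any effect.

Compound 4 `C=C1C[C@]23C[C@@]1(O)CC[C@H]2c1ccc(O)c(C)c1[C@@H]3Cn1cc(-c2ccc(Cl)cc2)nn1` differs from compound 3 by hydrogen in place of bromo on an aromatic carbon. Within the data shown here, no measured step involves this change, so there is no direct guide. The two compounds that lack this bromo, compound 1 and compound 2, both reach only the assay limit, whereas compound 3 carries it and gives a number. On that slim basis compound 4 is expected to move back toward the limit, a weakening. The estimated step is a 2.0-fold higher number from compound 3 to compound 4 (0.29 log units; within the scatter). For compound 4 the expected value in this assay is 20000 nM, within a range from 8000 nM to 60000 nM, with a fair chance that only a limit is reported.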

Compound 4, half-maximal inhibitory concentration: > 20000 nM
Compound 4: a limit, no number; the forecaster's own chance of this, stated with the estimate: 65%; the middle value lies on the limit itself.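

Within the data shown here, compound 3 and compound 4 form the first pair that isolates the bromo on the aromatic carbon ortho to a hydroxy group, with the rest of the structure unchanged. In this assay, replacing that bromo with hydrogen gives an at least 1.9-fold higher number from compound 3 to compound 4 (0.29 log units; that floor lies within the scatter); compound 4 ends at a limit, so this is only a floor, and the pair hints at a role for the bromo without establishing one. The steps among compound 1, compound 2 and compound 4 cannot be read, and these three compounds without the bromo share one ceiling: the limit of > 20000 nM in this assay, at which 3 of the 4 values shown sit.

As far as these compounds go, the true size of the loss stays open, as does whether adding this bromo to compound 1 or compound 2 would also bring a measurable number. From the compounds shown here alone, how an amine, a methoxy group or a carboxylic acid would compare at this position also remains open.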